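Methyl for Diethylamino on a Corticotropin-Releasing Factor Receptor Ligand

A few compounds are considered here, and "the series" means these few. Any claim that something is new, unique, unknown or untested is made for them only; others in the source may bear on it.

Compound 1, `CCN(c1nc(C)cc(C)n1)c1c(Br)cc(C(C)C)cc1OC`, gives 26 nM.
Compound 2, `CCN(CC)c1cc(C)nc(N(CC)c2c(Br)cc(C(C)C)cc2SC)n1`, gives 26 nM.

Both were tested in an assay on isolated protein for binding affinity to corticotropin-releasing factor receptor 1 (Homo sapiens); on this read-out lower numbers stand for stronger inhibition and higher numbers for weaker inhibition. Compound 2 stands level with compound 1 at the digits shown; the two values sit within the usual scatter of repeated measurements, so no difference between them can be claimed.

The unmeasured compound 3, `CCN(c1nc(C)cc(C)n1)c1c(Br)cc(C(C)C)cc1SC`, is derived from compound 2 by one change: methyl in place of diethylamino on an aromatic carbon. The change sits on the shared core, next to the ring nitrogen and meta to a methyl group. Within the data shown here, no step of this kind between measured compounds is available, so its size is unknown; with compound 1 at 26 nM and compound 2 at 26 nM, a step no larger than the scatter is the plainest expectation.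

Compound 3 is therefore expected to give about 25 nM in this assay, most likely between 8 nM and 80 nM, a step of a 1.0-fold lower number from compound 2 to compound 3 (0.02 log units; within the scatter).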

Compound 3, inhibition constant: 51 nM
Compound 3: the middle estimate sits 2.0-fold (0.31 log units) below what was measured; measured number inside the range.
By their numbers in this assay, from the lowest: compounds 1, 2 and 3 (each within the scatter of the next).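

In this assay, putting methyl in place of diethylamino on this aromatic carbon gives a 2.0-fold higher number from compound 2 to compound 3 (0.29 log units; within the scatter) and so shows no change that can be told from the scatter, even though a group of 5 heavy atoms with 1 hydrogen-bond acceptor gives way to a group of 1 heavy atom with none. The swap of methoxy for methylsulfanyl, now readable as well, gives a 2.0-fold higher number from compound 1 to compound 3 (0.29 log units; within the scatter) and likewise stays within the scatter. Nothing measured here offers an explanation for either result.

Going by these compounds, whether this position would accept a very different group, such as a carboxylic acid or a morpholine ring, remains open. On these data alone, it is also open whether the swap of diethylamino for methyl would read the same with methoxy in place of methylsulfanyl.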